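The compounds below may be only part of what the source reports. "The series", "measured", "known", "first", "only" and "open" are said of these compounds alone.

Among the compounds with values here, compound 1 `CCCSc1nnc(COc2ccccc2C2=NOC(c3ccc(Cl)cc3Cl)C2)n1NC(=O)CCl` gives 28.7 ug/mL in an ADME assay (MDM cells, Homo sapiens) for cytotoxicity, read by resazurin assay, with a stated time of 3 days (a lower number here means a stronger inhibitor, a higher number a weaker inhibitor), the only number in the set. Compound 2 `CC(C)CSc1nnc(COc2ccccc2C2=NOC(c3ccc(Cl)cc3Cl)C2)n1NC(=O)c1ccccc1` stands nowhere on this scale: in this assay compound 2 gives "not determined" (no result reported), so no result for it was reported. Compound 3 `CCCSc1nnc(COc2ccccc2C2=NOC(c3ccc(Cl)cc3Cl)C2)n1NC(=O)c1ccccc1` differs from compound 2 by a single change, (hydrogen in place of methyl on a saturated chain carbon bound to two saturated chain carbons). Within the data shown here, with no measured pair of this kind, the step from compound 2 to compound 3 in this assay is expected to be small, likely within the usual scatter, in either direction. Resting on the value of compound 1, compound 3 is expected to show about 40 ug/mL in this assay, within a range of 15 ug/mL to 110 ug/mL.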

Compound 3, half-maximal inhibitory concentration: 14.8 ug/mL
Compound 3: the middle estimate sits 2.7-fold (0.43 log units) above what was measured; the measured number lies below the stated range.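

With the propylsulfanyl group shared, phenyl in place of chloromethyl on the carbonyl carbon gives a 1.9-fold lower number from compound 1 to compound 3 (0.29 log units; within the scatter) in this assay and so does not separate the two compounds. This position can therefore carry either an open-chain chloromethyl or a phenyl ring with no difference beyond the scatter. Nothing available explains this result.

The step from isobutylsulfanyl to propylsulfanyl cannot be read, as compound 2 has no reported number. As far as these compounds go, how an amine or a carboxylic acid on the carbonyl carbon, or a longer chain on the sulfur, would read here remains open.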